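The source may hold more compounds than are shown below. What is called first, only, known or untested is meant among the compounds shown, and "the series" means these compounds.

Compound 3, `CC(C)c1ccc2oc(-c3ccc([N+](=O)[O-])cc3)cc(=O)c2c1`, carries a nitro group on its outer ring. In a functional assay on HepG2 cells (Homo sapiens) for cytotoxicity, read by MTT assay (a lower number here means a stronger inhibitor, a higher number a weaker inhibitor), compound 3 gives > 50000 nM, which is a limit of the assay rather than a number. Compound 2, `CC(C)c1ccc2oc(-c3cccc([N+](=O)[O-])c3)cc(=O)c2c1`, also carries a nitro group. In this assay compound 2 gives > 50000 nM, again a limit. Compound 3 thus stands at the limit of > 50000 nM in this assay, at which 2 of the 3 values shown sit, with no measured number of its own. Among the compounds with values here, the one compound with a number, compound 1, `COc1cc(OC)cc(-c2cc(=O)c3cc(Cl)ccc3o2)c1`, has two methoxy groups on its outer ring and a different core; in this assay compound 1 gives 1100 nM. Compound 4, `COc1ccc(-c2cc(=O)c3cc(C(C)C)ccc3o2)cc1`, arises from compound 3 by methoxy in place of nitro on an aromatic carbon. Within the data shown here, no measured pair shows this exchange on its own, so its size can only be guessed. Since compound 1 reaches 1100 nM with methoxy groups present, a move to a lower number is expected in this assay, though the core also differs. Compound 4 is therefore estimated at 12000 nM, most likely between 2000 nM and 50000 nM. That expectation amounts to a step of an at least 4.1-fold lower number from compound 3 to compound 4 (0.61 log units; beyond the scatter).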

Compound 4, half-maximal inhibitory concentration: 9900 nM
Beside the measured number, compound 4's estimate is 1.2-fold (0.08 log units) above it; low and high end bracket the measured number.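

With the shared core held constant, methoxy in place of nitro, on an aromatic carbon para to a large group, gives an at least 5.0-fold lower number from compound 3 to compound 4 (0.70 log units; beyond the scatter) in this assay. Compound 4 thus shows that this core can give a measured number in this assay, which compound 2 and compound 3 could not show, as both stop at a limit. The true size of the step stays unknown because the value for compound 3 is a limit and not a number: the limit of > 50000 nM in this assay, at which 2 of the 4 values shown sit.

As far as these compounds go, it remains open whether the lower number comes from the arrival of methoxy or simply from the loss of nitro. An unsubstituted ring carbon, an amine or a hydroxyl group at this place would help to separate those two readings.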